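The source may report more compounds than this note shows. Statements on the series, on what has been measured and on what is new or still open speak of the compounds shown alone.

Compound 1 `CCC1(Cc2ccccc2)OS(=O)(=O)C=C1OCC(=O)OC` — > 200000 nM
Compound 2 `CCC1(Cc2ccccc2)OS(=O)(=O)C=C1OCC#N` — > 200000 nM
Compound 3 `CCC1(Cc2ccccc2)OS(=O)(=O)C=C1OCCCc1ccccc1` — 133000 nM

Within the data shown here, in an ADME assay on HEL cells (Homo sapiens) for cytotoxicity, with a stated time of 3 days (a higher number here means that more compound is tolerated, a lower number that less compound is tolerated), compound 3 gives 133000 nM, the only true number among the three values shown. The value of compound 1, > 200000 nM, is a limit of the assay. The value of compound 2, > 200000 nM, is likewise a limit. Both sit at the limit of > 200000 nM in this assay, at which 2 of the 3 values shown sit. Among the measured compounds shown here, the steps of an at least 1.5-fold lower number from compound 1 to compound 3 (0.17 log units; that floor lies within the scatter) and an at least 1.5-fold lower number from compound 2 to compound 3 (0.17 log units; that floor lies within the scatter) are therefore only floors, and each floor lies within the scatter, so no measured step here shows a change beyond the scatter. The step that the two limits leave unreadable from compound 1 to compound 2 cannot be read at all.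

Compound 4 `CCC1(Cc2ccccc2)OS(=O)(=O)C=C1OCCCCCCc1ccccc1` differs from compound 3 by 3-phenylpropyl in place of phenyl on a saturated chain carbon, three bonds along the chain from an oxygen on an unsaturated carbon. For the measured compounds named here, no measured step touches this position; all three exchange the group on the saturated chain carbon bound to the oxygen. With nothing pointing to a change, compound 4 is expected to sit near compound 3, with a step of a 1.3-fold lower number from compound 3 to compound 4 (0.12 log units; within the scatter) that stays within the scatter. Compound 4 is estimated at 100000 nM in this assay, within a range from 35000 nM to 250000 nM.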

Compound 4, half-maximal cytotoxic concentration: < 200000 nM
Compound 4: a limit, no number; the forecaster's own chance of this, stated with the estimate: 25%; the middle value lies beyond the limit too.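

In this assay compound 4 gives < 200000 nM, which is a limit and not a number. Among these compounds, no step from compound 3 to compound 4 can therefore be read. The compounds shown leave open whether 3-phenylpropyl in place of phenyl changes how much compound is tolerated.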